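Amine exchange on compound 1: compound 4 expected

The source may report more compounds than this note shows. Statements on the series, on what has been measured and on what is new or still open speak of the compounds shown alone.

Measured so far:
compound 1 `OCc1cc(N2CCCC2)ccc1-c1nc2c(s1)C(O)CCC2` — 56 nM
compound 2 `CN(C)c1ccc(-c2nc3c(s2)C(O)CNC3)c(CO)c1` — 31 nM
compound 3 `OC1CCCc2nc(-c3ccc(N4CCCC4)cc3)sc21` — 8700 nM

All three were run in a functional assay on MCF7 cells (Homo sapiens) for cytotoxicity, read by sulforhodamine B assay, with a stated time of 2 days; on this read-out higher numbers stand for weaker inhibition and lower numbers for stronger inhibition. Compound 1 gives 56 nM and stands second highest of the three numbers; compound 2 with 31 nM lies within the scatter of it, while compound 3 with 8700 nM lies far beyond. Among the compounds with values here, the only single-place step among the measured compounds is a 160-fold higher number from compound 1 to compound 3 (2.19 log units; beyond the scatter), the removal of the hydroxymethyl group, and it is large.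

Compound 4 `CN(C)c1ccc(-c2nc3c(s2)C(O)CCC3)c(CO)c1` keeps the hydroxymethyl group and differs from compound 1 in the amine alone: dimethylamino in place of pyrrolidin-1-yl on an aromatic carbon. Within the data shown here, no measured step isolates this exchange. Compound 2 carries the dimethylamino group but also a different saturated ring in the shared core, so its value set against compound 1 reflects both changes together, and those two values fall within the scatter of each other. With the amine exchange untested on its own and the nearest comparison showing no difference beyond the scatter, the step of a 1.2-fold lower number from compound 1 to compound 4 (0.09 log units; within the scatter) is expected to stay within the scatter. Compound 4 is therefore estimated at 45 nM, with a range from 15 nM to 150 nM.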

Compound 4, half-maximal inhibitory concentration: 360 nM
Compound 4: the middle estimate sits 8.0-fold (0.90 log units) below what was measured, outside the stated range (above it).
By their numbers in this assay, from the lowest: compounds 2 and 1 (each within the scatter of the next); then compound 4; then compound 3.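

In this assay the amine on this aromatic carbon, para to a large group, proves not to be a silent position, since a 6.4-fold higher number from compound 1 to compound 4 (0.81 log units; beyond the scatter) comes with dimethylamino in place of pyrrolidin-1-yl alone, the hydroxymethyl group staying in place. Within the data shown here, that modest step is still smaller than a 160-fold higher number from compound 1 to compound 3 (2.19 log units; beyond the scatter) on removal of the hydroxymethyl group, so the series so far loses less on this amine exchange than on that removal. With the same dimethylamino group, compound 2 gives 31 nM and compound 4 gives 360 nM in this assay, so the closeness of compound 1 and compound 2 masked the amine step, and dimethylamino alone does not fix a weak value across different cores.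

Open, on these data alone, is whether other cyclic amines, such as piperidin-1-yl, morpholin-4-yl or azetidin-1-yl, match pyrrolidin-1-yl here, and whether the amine step keeps its size in the core of compound 2. Nothing at hand accounts for the step from pyrrolidin-1-yl to dimethylamino.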